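The source may hold more compounds than are shown below. What is called first, only, known or untested is meant among the compounds shown, and "the series" means these compounds.

Measured so far:
compound 1, `CC(C)n1nccc1-c1ccccc1NCC1=NCCN1`, with 0% in a functional assay with Alpha-1B adrenergic receptor (Homo sapiens) as the target, read by calcium flux; on this read-out higher numbers stand for larger maximal responses and lower numbers for smaller maximal responses
compound 2, `c1ccc(-c2nc[nH]n2)c(NCC2=NCCN2)c1`, with 100% in this assay

Compound 2 stands highest of the two numbers; its nearest neighbour is compound 1, which lies lower, a gap beyond the scatter. Compound 3, `Cn1nccc1-c1ccccc1NCC1=NCCN1`, has not been measured in this assay. It differs from compound 2 in one place: 1-methyl-1H-pyrazol-5-yl in place of 1H-1,2,4-triazol-3-yl on an aromatic carbon. Going by the values given here, no step between two measured compounds covers this exact change, so the account can only lean on what compound 1 and compound 2 show. Compound 1 carries a 1-isopropyl-1H-pyrazol-5-yl group at the same place and gives 0%, while compound 2 gives 100%. Compound 3 sits between them in structure, so a drop from compound 2 is expected, of size a number 60 percentage points lower from compound 2 to compound 3 (beyond the scatter). Compound 3 is estimated at 40%, with a range from 5% to 85%.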

Compound 3, largest response reached (reported as maximal response), in percent of the reference or control that the assay uses: 0%
Estimate against measurement, compound 3: 40 percentage points above; the measured number lies below the stated range.
By their numbers in this assay, from the lowest: compounds 1 and 3 (each within the scatter of the next); then compound 2.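

In this assay, 1-methyl-1H-pyrazol-5-yl in place of 1H-1,2,4-triazol-3-yl on this aromatic carbon gives a number 100 percentage points lower from compound 2 to compound 3 (beyond the scatter), so the response seen with compound 2 does not carry over to this pyrazole. Methyl in place of isopropyl on the aromatic nitrogen gives no change at the digits printed from compound 1 to compound 3 (within the scatter), which shows that the absence of response in compound 1 is not specific to isopropyl and is shared by the methyl and isopropyl pyrazoles. The data shown offer no independent evidence on why the response is lost.

Going by these compounds, this step changes the ring and the substituent on nitrogen together, so their separate contributions remain open. An unsubstituted 1H-pyrazol-5-yl or a 1-methyl-1H-1,2,4-triazol-5-yl at the same place would be needed to tell them apart.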